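The source may hold more compounds than are shown below. What is called first, only, known or untested is meant among the compounds shown, and "the series" means these compounds.

Measured so far in a functional assay on the whole organism (strain Wistar) with Rattus norvegicus as the target, with a stated time of 15 days, at a dose of 3 mg/kg by the oral route; a higher number here means a stronger effect of the compound at the dose given, a lower number a weaker effect:
compound 1 `O=C1NC(=O)/C(=C/c2ccc(OCCSc3nnc(Cc4ccccc4)[nH]3)cc2)S1` gives 22.5%
compound 2 `O=C1NC(=O)/C(=C/c2ccc(OCCSc3nnc(-c4ccc([N+](=O)[O-])cc4)[nH]3)cc2)S1` gives 14.1%
compound 3 `O=C1NC(=O)/C(=C/c2ccc(OCCSc3nnc(-c4ccccc4[N+](=O)[O-])[nH]3)cc2)S1` gives 19.8%

Compound 3 stands second highest of the three numbers in this assay, nearest to compound 1 and furthest from compound 2; both gaps are within the scatter, so the three compounds read as one level. The measured steps are a number 8.4 percentage points lower from compound 1 to compound 2 (within the scatter), a number 2.7 percentage points lower from compound 1 to compound 3 (within the scatter) and a number 5.7 percentage points higher from compound 2 to compound 3 (within the scatter); none of them leaves the scatter.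

Compound 4 `O=C1NC(=O)/C(=C/c2ccc(OCCSc3nnc(-c4ccc(Br)cc4)[nH]3)cc2)S1` differs from compound 3 in one place: 4-bromophenyl in place of 2-nitrophenyl on an aromatic carbon. The step that bears on it directly is the exchange of one nitrophenyl for the other on an aromatic carbon, a number 5.7 percentage points higher from compound 2 to compound 3 (within the scatter), and the two replacements of benzyl, a number 8.4 percentage points lower from compound 1 to compound 2 (within the scatter) and a number 2.7 percentage points lower from compound 1 to compound 3 (within the scatter), all within the scatter. Going by the values given here, no measured compound carries bromine, so the 4-bromophenyl has no precedent. The expectation is a step of about a number 1.8 percentage points lower from compound 3 to compound 4 (within the scatter) in this assay, not beyond the scatter. Compound 4 is estimated at 18%, with a range from 9% to 27%.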

Compound 4, a percentage reported as activity, at one dose (the size of the read-out at that dose, not a potency): 28.4%
For compound 4 the middle estimate is 10.4 percentage points below the measured one; the measured number lies above the stated range.
By their numbers in this assay, from the lowest: compounds 2, 3, 1 and 4 (each within the scatter of the next, the first and the last beyond it).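

In this assay, going by these compounds alone, bromo in place of nitro on an aromatic carbon gives a number 14.3 percentage points higher from compound 2 to compound 4 (beyond the scatter) as the first step to leave the scatter, a modest one. The other two comparisons stay inside it, with a number 8.6 percentage points higher from compound 3 to compound 4 (within the scatter) and a number 5.9 percentage points higher from compound 1 to compound 4 (within the scatter) as their steps, so the separation holds only against the 4-nitrophenyl of compound 2, and compound 4 reads on one level with compound 1 and compound 3. Nothing available explains why bromo and nitro part at this position.

Open, going by these compounds, is whether chloro or fluoro in place of bromo would stand with compound 4 or with compound 2. Also open, on these data alone, are how an amine or a carboxylic acid on the same phenyl ring would read, and whether 2-bromophenyl would match 4-bromophenyl.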